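From sec-butyl to isobutyl on an aromatic nitrogen

The source may hold more compounds than are shown below. What is called first, only, known or untested is meant among the compounds shown, and "the series" means these compounds.

In an ADME assay on Huh-7 cells (Homo sapiens) for cytotoxicity, with a stated time of 72 h (on this read-out higher numbers stand for lower toxicity in this test and lower numbers for higher toxicity in this test), compound 3 `CCC(C)n1nc(-c2cccs2)c(O)c(C2=NS(=O)(=O)c3cc(NS(C)(=O)=O)ccc3N2)c1=O` gives > 33000 nM, which is a limit and not a number. Compound 1 `CS(=O)(=O)Nc1ccc2c(c1)S(=O)(=O)N=C(c1c(O)c(-c3cccs3)nn(CCC3CC3)c1=O)N2` gives > 33000 nM, also a limit. Compound 2 `CC(C)CC(C)n1nc(-c2cccs2)c(O)c(C2=NS(=O)(=O)c3cc(NS(C)(=O)=O)ccc3N2)c1=O` gives > 33000 nM, again a limit. Compound 4 `CC(C)Cn1nc(-c2cccs2)c(O)c(C2=NS(=O)(=O)c3cc(NS(C)(=O)=O)ccc3N2)c1=O` differs from compound 3 by one change, isobutyl in place of sec-butyl on an aromatic nitrogen. The closest measured changes are a step that the two limits leave unreadable from compound 1 to compound 3 and a step that the two limits leave unreadable from compound 2 to compound 3, so neither offers a size to carry over. For compound 4 no step beyond the scatter is expected in this assay, since compound 1, compound 2 and compound 3 all share (the limit of > 33000 nM in this assay, at which 3 of the 3 values shown sit). The expected change is a step that the limit leaves unreadable from compound 3 to compound 4. Compound 4 is estimated at 40000 nM, with a range of 20000 nM to 80000 nM.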

Compound 4, half-maximal cytotoxic concentration: > 1000 nM
Compound 4 was reported as a limit; the forecaster's own chance of this, stated with the estimate: 90%; the middle value does not contradict the limit.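

Going by these compounds alone, compound 1, compound 2, compound 3 and compound 4 are all reported only as limits in this assay, so no step between them can be read. Where the true cytotoxic concentration of each compound lies stays open.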